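Nitro for Fluoro on a Quinoline Carboxanilide Core

The source may hold more compounds than are shown below. What is called first, only, known or untested is meant among the compounds shown, and "the series" means these compounds.

Three amides sharing one core were tested in an ADME assay on THP-1 cells (Homo sapiens) for cytotoxicity, read by WST assay, with a stated time of 24 h; a higher number here means a weaker inhibitor, a lower number a stronger inhibitor. Compound 1, `Cc1cccc(NC(=O)c2ccc3cccc(O)c3n2)c1`, gives only a limit of the assay in this assay, > 30000 nM. Compound 2, `O=C(Nc1cccc(F)c1)c1ccc2cccc(O)c2n1`, likewise reaches only a limit in this assay, > 30000 nM. Compound 3, `O=C(Nc1ccc(Cl)cc1)c1ccc2cccc(O)c2n1`, also stops at a limit in this assay, > 30000 nM. All three values therefore rest on the same ceiling, (the limit of > 30000 nM in this assay, at which 3 of the 3 values shown sit), and none of the three steps can be read: from compound 1 to compound 2 the step is a step that the two limits leave unreadable from compound 1 to compound 2, from compound 1 to compound 3 it is a step that the two limits leave unreadable from compound 1 to compound 3, and from compound 2 to compound 3 it is a step that the two limits leave unreadable from compound 2 to compound 3.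

The unmeasured compound 4, `O=C(Nc1cccc([N+](=O)[O-])c1)c1ccc2cccc(O)c2n1`, differs from compound 2 by one change: nitro in place of fluoro on an aromatic carbon, meta to a large group. The measured steps that bear on it, the exchanges among methyl, fluoro and chloro on the anilide ring, were all left unreadable by the limits, so they give no direction. With every value shown sitting at the ceiling, the step from compound 2 to compound 4 in this assay is expected to be a number no higher from compound 2 to compound 4 (the limit leaves the size open), that is, nothing beyond the scatter. Compound 4 is accordingly estimated to give 30000 nM in this assay, within a range from 15000 nM to 60000 nM, most likely reported again only as a limit.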

Compound 4, half-maximal inhibitory concentration: > 30000 nM
Compound 4 ended at the assay's limit; the forecaster's own chance of this, stated with the estimate: 85%; the middle value sits exactly at the limit.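

In this assay compound 4 gives > 30000 nM as a limit of the assay. Neither the step from compound 2 to compound 4 nor that from compound 1 to compound 4 can be read, because every value rests on one ceiling: the limit of > 30000 nM in this assay, at which 4 of the 4 values shown sit.

The compounds shown leave open how methyl, fluoro, chloro and nitro rank against one another in this assay at all.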